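The compounds below may be only part of what the source reports. "The series", "measured", "known", "first", "only" and "open" are said of these compounds alone.

In a functional assay on A549 cells (Homo sapiens) for cytotoxicity, read by XTT assay, with a stated time of 72 h (on this read-out higher numbers stand for weaker inhibition and lower numbers for stronger inhibition), compound 1 (`CC(C)=CCC/C=C(\C)Cc1c(O)cc(O)c2c(=O)c(OC/C=C(\C)CCC=C(C)C)c(-c3ccc(O)cc3)oc12`) gives 26000 nM and compound 2 (`CC(C)=CCC/C(C)=C/COc1c(-c2ccc(O)cc2)oc2cc(O)cc(O)c2c1=O`) gives 27000 nM. For the measured compounds named here, these two values lie within the scatter of each other, so compound 1 holds no clear rank on the numbers so far. Compound 3 (`CC(C)=CCC/C=C(\C)Cc1c(O)cc(O)c2c(=O)c(O)c(-c3ccc(O)cc3)oc12`) has not yet been measured. It differs from compound 1 by hydrogen in place of 3,7-dimethylocta-2,6-dien-1-yl on an oxygen on an aromatic ring, so that (3,7-dimethylocta-2,6-dien-1-yl)oxy becomes hydroxy. Going by the values given here, only one measured step bears on this change, and only indirectly: a 1.0-fold higher number from compound 1 to compound 2 (0.02 log units; within the scatter). That step removes a chain on an aromatic carbon, not the chain on oxygen, so it cannot settle what this removal will do. With so little evidence, no step beyond the scatter is expected, and the estimated step is a 1.3-fold lower number from compound 1 to compound 3 (0.11 log units; within the scatter). The expected value for compound 3 is 20000 nM, within an estimated range of 6000 nM to 55000 nM.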

Compound 3, half-maximal inhibitory concentration: 26000 nM
The estimate for compound 3 lay 1.3-fold (0.11 log units) below the measured number, within the range that was stated.
By their numbers in this assay, from the lowest: compounds 1, 3 and 2 (each within the scatter of the next).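

Replacing the (3,7-dimethylocta-2,6-dien-1-yl)oxy group with hydroxy leaves the result in this assay unchanged, with no change at the digits printed from compound 1 to compound 3 (within the scatter). For the compounds shown here, the earlier step concerned only the chain on an aromatic carbon, so this is the first direct reading for the chain on the oxygen: taking it away alone produces no step beyond the scatter. No measurement shown here explains why the number holds steady. Still open, as far as these compounds go, is whether this oxygen tolerates other groups, such as a methyl group, a longer chain, or a chain ending in an amine or a carboxylic acid. The compounds shown also cannot tell what happens with both 10-carbon chains absent from the shared core at once.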